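The source may hold more compounds than are shown below. What is called first, only, known or untested is meant among the compounds shown, and "the series" means these compounds.

Working notes on the series: in a functional assay on CCRF-CEM cells (Homo sapiens) for inhibition, read by MTT assay, with a stated time of 72 h (on this read-out lower numbers stand for stronger inhibition and higher numbers for weaker inhibition), compound 1 (`C=C(Br)C(=O)Nc1cccc(/C=C/C(=O)Nc2ccccc2)c1`) gives 190 nM, the middle of three numbers, with compound 2 (`C=C(Br)C(=O)Nc1cccc(/C=C/C(=O)Nc2cccc3ccccc23)c1`) at 1800 nM and compound 3 (`C=C(Br)C(=O)Nc1cccc(/C=C/C(=O)Nc2ccc(OC)cc2)c1`) at 26 nM. Compound 4 (`C=C(Br)C(=O)Nc1cccc(/C=C/C(=O)Nc2ccc(SC(F)(F)F)cc2)c1`) is still unmeasured. It differs from compound 1 by (trifluoromethyl)sulfanyl in place of hydrogen on an aromatic carbon, para to a large group: (trifluoromethyl)sulfanyl in place of hydrogen on an aromatic carbon. For the measured compounds named here, the only measured step bearing on this is methoxy in place of hydrogen, a 7.3-fold lower number from compound 1 to compound 3 (0.86 log units; beyond the scatter), which involves a different group and so guides direction only weakly. A smaller step towards lower numbers is therefore expected in this assay. The expected step is a 2.7-fold lower number from compound 1 to compound 4 (0.43 log units; beyond the scatter). For compound 4 the estimated value is 70 nM, with an expected range of 15 nM to 300 nM.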

Compound 4, half-maximal inhibitory concentration: 15300 nM
Compound 4: middle estimate off by 220-fold (2.34 log units), on the low side, outside the stated range (above it).
By their numbers in this assay, from the lowest: compound 3; then compound 1; then compound 2; then compound 4.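

In this assay, the aromatic carbon para to a large group turns out to tolerate change in both directions: (trifluoromethyl)sulfanyl in place of hydrogen gives an 81-fold higher number from compound 1 to compound 4 (1.91 log units; beyond the scatter), against the opposite direction of a 7.3-fold lower number from compound 1 to compound 3 (0.86 log units; beyond the scatter). Replacing methoxy with (trifluoromethyl)sulfanyl at this place gives a 590-fold higher number from compound 3 to compound 4 (2.77 log units; beyond the scatter), so the identity of the group here largely sets the number. No supporting measurement bears on the reason for this reversal.

On these data alone, how an amine or a carboxylic acid at this place would read remains open. So does whether ethoxy, a longer chain, would stay close to methoxy.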